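From isopropylcarbonyl to benzylsulfonyl on a shared core

This account rests on a few compounds, and the source may have more. Where it says the series, first, only, none or still open, it means among the compounds named here.

Three measured compounds share one core and differ only in the group on an oxygen on an aromatic ring. Compound 1 `COc1ccc(/C=C/C(=O)c2ccc(OC)c3c2OC(C)(C)C=C3)cc1OCCO` carries a 2-hydroxyethyl there; in an ADME assay on L02 cells (Homo sapiens) for cytotoxicity, read by MTT assay (on this read-out higher numbers stand for weaker inhibition and lower numbers for stronger inhibition), compound 1 gives a value that is a limit of the assay, > 10000 nM. Compound 2 `CCCCC(=O)Oc1cc(/C=C/C(=O)c2ccc(OC)c3c2OC(C)(C)C=C3)ccc1OC` carries a butylcarbonyl, and compound 2 is reported only as the limit > 10000 nM. Compound 3 `COc1ccc(/C=C/C(=O)c2ccc(OC)c3c2OC(C)(C)C=C3)cc1OC(=O)C(C)C` carries an isopropylcarbonyl, and compound 3 likewise is reported only as the limit > 10000 nM. The steps among them remain unreadable, a step that the two limits leave unreadable from compound 1 to compound 2, a step that the two limits leave unreadable from compound 1 to compound 3 and a step that the two limits leave unreadable from compound 2 to compound 3, because every value sits at the limit of > 10000 nM in this assay, at which 3 of the 3 values shown sit.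

Compound 4 `COc1ccc(/C=C/C(=O)c2ccc(OC)c3c2OC(C)(C)C=C3)cc1OS(=O)(=O)Cc1ccccc1` differs from compound 3 by benzylsulfonyl in place of isopropylcarbonyl on an oxygen on an aromatic ring. Among the compounds with values here, no measured step gives a size for such a change, since each value stops at the limit. Compound 3 stands at that limit together with compounds 1 and 2. Compound 4 is therefore expected to show a step that the limit leaves unreadable from compound 3 to compound 4 that stays small and most likely leaves the value again past the limit. Compound 4 is expected to give about 30000 nM in this assay, within 8000 nM to 120000 nM.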

Compound 4, half-maximal inhibitory concentration: > 10000 nM
Compound 4 was reported as a limit; the forecaster's own chance of this, stated with the estimate: 80%; the middle value is on the limit's open side.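

Compound 4 gives > 10000 nM in this assay as a limit of the assay. Its steps to compound 1, compound 2 and compound 3 cannot be read, since every value stops there: the limit of > 10000 nM in this assay, at which 4 of the 4 values shown sit.

The compounds shown leave open whether in this assay the groups on an oxygen on an aromatic ring differ at all.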